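Swapping an ortho methoxy for methyl on the anilide ring

This account rests on a few compounds, and the source may have more. Where it says the series, first, only, none or still open, it means among the compounds named here.

Measured compounds in a functional assay on Huh-7 cells (Homo sapiens) for inhibition, read by MTT assay, with a stated time of 48 h; a higher number here means a weaker inhibitor, a lower number a stronger inhibitor:
- compound 1 `COc1ccc2c(=O)c(/C=C/C(=O)NCc3ccccc3)coc2c1`: 13600 nM
- compound 2 `COc1ccc2c(=O)c(/C=C/C(=O)Nc3cc(C)ccc3C)coc2c1`: 11100 nM
- compound 3 `COc1ccc2c(=O)c(/C=C/C(=O)Nc3ccccc3OC)coc2c1`: 32300 nM

Compound 3 gives the highest number of the three in this assay, so it is the weakest inhibitor measured so far. Compound 4 `COc1ccc2c(=O)c(/C=C/C(=O)Nc3ccccc3C)coc2c1` differs from it in one place: methyl in place of methoxy on an aromatic carbon. The step that bears most on this is a 2.9-fold higher number from compound 2 to compound 3 (0.46 log units; beyond the scatter), where a ring carrying two methyl groups gave a lower number than the methoxy-bearing ring; a 2.4-fold higher number from compound 1 to compound 3 (0.38 log units; beyond the scatter) points the same way. Compound 4 sits between compound 2 and compound 3 in structure, so a modest drop in number is expected, about a 2.2-fold lower number from compound 3 to compound 4 (0.33 log units; beyond the scatter). Compound 4 is therefore estimated at 15000 nM in this assay, with a range from 7000 nM to 32000 nM.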

Compound 4, half-maximal inhibitory concentration: 26900 nM
Compound 4: the middle estimate sits 1.8-fold (0.25 log units) below what was measured; the measured number falls inside the stated range.
By their numbers in this assay, from the lowest: compounds 2, 1, 4 and 3 (each within the scatter of the next, the first and the last beyond it).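

In this assay methyl in place of methoxy on this aromatic carbon, ortho to a large group, gives a 1.2-fold lower number from compound 3 to compound 4 (0.08 log units; within the scatter) so the two groups cannot be told apart here. The second methyl of compound 2 does count, with hydrogen in its place giving a 2.4-fold higher number from compound 2 to compound 4 (0.38 log units; beyond the scatter) as the result. The 2-methylphenyl amide gives a 2.0-fold higher number from compound 1 to compound 4 (0.30 log units; within the scatter) and so is not set apart from the benzyl amide. Going by these compounds, whether an ethoxy or an amine on this carbon would behave the same stays open. No measurement shown gives a reason for these steps.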